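A few compounds are considered here, and "the series" means these few. Any claim that something is new, unique, unknown or untested is made for them only; others in the source may bear on it.

Compound 1 `CCCC(C)(C)/N=C(\NC#N)Nc1cccnc1` — 1 mg/kg
Compound 2 `CC1(/N=C(\NC#N)Nc2cccnc2)CCC1` — 50 mg/kg

In a functional assay on the whole organism (blood, strain Wistar-Okamoto) with Rattus norvegicus as the target, with a stated time of 5 days (on this read-out lower numbers stand for an effect already at smaller amounts and higher numbers for an effect only at larger amounts of compound), compound 2 gives 50 mg/kg, the highest of the two numbers, while compound 1 gives 1 mg/kg. For the measured compounds named here, the one measured step, a 50-fold higher number from compound 1 to compound 2 (1.70 log units; beyond the scatter), shows that changing the group on the double-bonded nitrogen can shift the result strongly. Compound 3 `CCOCC/N=C(\NC#N)Nc1cccnc1` brings a further change at that same place: 2-ethoxyethyl in place of 1-methylcyclobutyl on a double-bonded nitrogen. Going by the values given here, no measured step involves the 2-ethoxyethyl group, so the earlier step only signals that this position matters, not which way. Compound 3 is therefore expected to stay close to compound 2, with the step of a 1.7-fold lower number from compound 2 to compound 3 (0.22 log units; within the scatter) within the scatter, giving an estimated 30 mg/kg (range 5 mg/kg to 100 mg/kg).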

Compound 3, minimum effective dose: > 20 mg/kg
Compound 3 was reported as a limit (the forecaster's own chance of this, stated with the estimate: 20%); the middle value lies beyond the limit too.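

Replacing 1,1-dimethylbutyl with 2-ethoxyethyl on the double-bonded nitrogen gives an at least 20-fold higher number from compound 1 to compound 3 (1.30 log units; beyond the scatter). So a large rise at this position does not require the four-membered ring of compound 2, since compound 3 has no ring and still stands far from compound 1. Compound 3 is reported only as a limit, so its step from compound 2 cannot be read: the limit of > 20 mg/kg in this assay, at which 1 of the 3 values shown sits.

On these data alone, it remains open whether compound 3 differs from compound 2 at all. The compounds shown also leave open what a plain longer chain or a chain carrying an amine would give at this position.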